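Adding a methoxy group to compound 3

This account rests on a few compounds, and the source may have more. Where it says the series, first, only, none or still open, it means among the compounds named here.

Values from a functional assay on H184B5F5/M10 cells (Homo sapiens) for antiproliferative activity, read by MTT assay, with a stated time of 24 h (a higher number here means a weaker inhibitor, a lower number a stronger inhibitor), follow here
- Compound 1 (`COc1ccc(C(=O)NNC(=O)/C=C/c2ccc(O)cc2)cc1`) gives 8440 nM in this test
- Compound 2 (`COc1ccc(C(=O)NNC(=O)/C=C/c2ccc(O)c(OC)c2)cc1`) gives > 10000 nM as a limit of the assay
- Compound 3 (`O=C(/C=C/c1ccc(O)c(O)c1)NNC(=O)c1ccccc1`) gives 8120 nM in this test

Compound 3 and compound 1 lie within the scatter of each other, and compound 2 supplies only a limit. Compound 4 (`COc1ccc(C(=O)NNC(=O)/C=C/c2ccc(O)c(O)c2)cc1`) differs from compound 3 by one change (methoxy in place of hydrogen on an aromatic carbon), methoxy in place of hydrogen on an aromatic carbon. For the measured compounds named here, the only measured step of this kind sits at another place in the molecule (an at least 1.1-fold higher number from compound 1 to compound 2 (0.07 log units; that floor lies within the scatter)) and is bounded by a limit (the limit of > 10000 nM in this assay, at which 1 of the 3 values shown sits). On that step, no shift beyond the scatter is expected in this assay for this change. The expected step is a 1.0-fold higher number from compound 3 to compound 4 (0.02 log units; within the scatter) in this estimate. Compound 4 is estimated at 8500 nM in this test. The expected range for compound 4 runs from 4500 nM to 15000 nM in this test.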

Compound 4, half-maximal inhibitory concentration: 9570 nM
For compound 4 the middle estimate is 1.1-fold (0.05 log units) below the measured one; the measured number falls inside the stated range.
By their numbers in this assay, from the lowest: compounds 3, 1 and 4 (each within the scatter of the next). At a limit, above all of these: compound 2.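

In this assay, methoxy in place of hydrogen on an aromatic carbon, para to a large group, now gives a step with two measured ends, a 1.2-fold higher number from compound 3 to compound 4 (0.07 log units; within the scatter), and so the change has a size here that no limit bounds. On the core of compound 1, hydroxy in place of hydrogen also stays small, at a 1.1-fold higher number from compound 1 to compound 4 (0.05 log units; within the scatter). The remaining step, an at least 1.0-fold lower number from compound 2 to compound 4 (0.01 log units; that floor lies within the scatter), cannot be read, since its starting value is a limit: the limit of > 10000 nM in this assay, at which 1 of the 4 values shown sits.

Going by these compounds, whether an amine or a carboxylic acid at this position would move the number beyond the scatter remains open.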